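This account rests on a few compounds, and the source may have more. Where it says the series, first, only, none or still open, it means among the compounds named here.

Within the data shown here, compound 1 `CNc1nc(-n2cc(-c3ccccn3)nn2)nc2c1ncn2[C@@H]1O[C@H](CO)[C@@H](O)[C@H]1O` is one of two compounds measured in an assay on CHO cells for displacement of a labelled ligand from adenosine receptor A1 (Homo sapiens); on this read-out higher numbers stand for weaker inhibition and lower numbers for stronger inhibition. In this assay compound 1 gives 1970 nM, the higher of the two numbers. Among the measured compounds shown here, the other measured compound, compound 2 `CCNC(=O)[C@H]1O[C@@H](n2cnc3c(NC)nc(-n4cc(Cc5ccccc5)nn4)nc32)[C@H](O)[C@@H]1O`, differs from compound 1 in more than one place, so no single step connects them; in this assay compound 2 gives 510 nM, a lower number, and the gap between the two lies beyond the usual scatter. Compound 3 `CCc1cn(-c2nc(NC)c3ncn([C@@H]4O[C@H](CO)[C@@H](O)[C@H]4O)c3n2)nn1` has not yet been measured. It is derived from compound 1 by a single change: ethyl in place of pyridin-2-yl on an aromatic carbon. For the measured compounds named here, no measured pair shows this change alone, so nothing in hand tells how it will turn out. A modest step downward a 2.0-fold lower number from compound 1 to compound 3 (0.29 log units; within the scatter) in this assay is expected, with wide uncertainty. Compound 3 is therefore estimated at 1000 nM, in a range from 250 nM to 4000 nM.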

Compound 3, inhibition constant: 2920 nM
The estimate for compound 3 lay 2.9-fold (0.47 log units) below the measured number; measured number inside the range.
By their numbers in this assay, from the lowest: compound 2; then compounds 1 and 3 (each within the scatter of the next).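

At this aromatic carbon, ethyl in place of pyridin-2-yl removes a six-membered aromatic ring and its hydrogen-bond acceptor, yet in this assay the change amounts to a 1.5-fold higher number from compound 1 to compound 3 (0.17 log units; within the scatter) and leaves the two compounds indistinguishable. For this one pair, then, the pyridin-2-yl ring is not needed to hold the number where it stands, and a group of 2 heavy atoms reads much like one of 6. Nothing in hand explains why the two groups read alike here.

On these data alone, whether a longer chain such as butyl, an amine or a carboxylic acid would read the same at this position remains open. As far as these compounds go, it is also open whether ethyl would behave this way on the core of compound 2, which differs from compound 1 in more than one place.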